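Swapping fluoro for pyridin-4-yl in a two-compound series

The source may hold more compounds than are shown below. What is called first, only, known or untested is meant among the compounds shown, and "the series" means these compounds.

- compound 1 `N#Cc1ccc(NC(=O)c2ccc(-c3ccccc3)cc2O)cc1`: 700 nM
- compound 2 `N#Cc1ccc(NC(=O)c2ccc(F)cc2O)cc1`: 1380 nM
- compound 3 `N#Cc1ccc(NC(=O)c2ccc(-c3ccncc3)cc2O)cc1`: not yet measured

In a functional assay on HL-60 cells (Homo sapiens) for cytotoxicity, read by luminescence and CellTiter-Glo, with a stated time of 3 days (a lower number here means a stronger inhibitor, a higher number a weaker inhibitor), compound 2 gives 1380 nM, a number that cannot be told apart from that of compound 1. Compound 3 changes one group: pyridin-4-yl in place of fluoro on an aromatic carbon. For the measured compounds named here, the one measured step that bears on this is fluoro in place of phenyl, a 2.0-fold higher number from compound 1 to compound 2 (0.29 log units; within the scatter). Compound 3 carries a six-membered aromatic ring at that place, as compound 1 does at 700 nM, so no step beyond the scatter is expected in this assay. The expected step is a 1.7-fold lower number from compound 2 to compound 3 (0.24 log units; within the scatter). Compound 3 is estimated at 800 nM, with an expected range from 300 nM to 2000 nM.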

Compound 3, half-maximal inhibitory concentration: 7090 nM
Estimate against measurement, compound 3: 8.9-fold (0.95 log units) below; the measured number lies above the stated range.
By their numbers in this assay, from the lowest: compounds 1 and 2 (each within the scatter of the next); then compound 3.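

In this assay this position does not treat all six-membered aromatic rings alike: swapping phenyl for pyridin-4-yl gives a 10-fold higher number from compound 1 to compound 3 (1.01 log units; beyond the scatter) for a change of one ring atom. Pyridin-4-yl also compares poorly with the much smaller fluoro, with a 5.1-fold higher number from compound 2 to compound 3 (0.71 log units; beyond the scatter) on that swap, so ring size alone does not set the number here. Nothing measured here gives a reason for this loss of activity. Going by these compounds, whether a pyridin-3-yl group or a phenyl ring carrying an amine would behave like phenyl or like pyridin-4-yl stays open.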